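The source may hold more compounds than are shown below. What is called first, only, known or untested is meant among the compounds shown, and "the series" means these compounds.

Measured in an ADME assay on Raji cells (Homo sapiens) for cytotoxicity, read by CellTiter-Glo and resazurin assay, with a stated time of 72 h; on this read-out lower numbers stand for an effect already at smaller amounts and higher numbers for an effect only at larger amounts of compound:
compound 1 `CCOC(=O)CCCCCOc1cccc(CN(C(=O)c2ccc(-c3cccc(-c4ccccc4)c3)cc2)C(C)C)c1`: > 26000 nM, a limit of the assay, not a number
compound 2 `CCOC(=O)CCCCCOc1cccc(CN(C(=O)c2ccc(-c3cccc(-c4nnc(C)o4)c3)cc2)C(C)C)c1`: > 26000 nM, likewise a limit
compound 3 `CCOC(=O)CCCCCOc1cccc(CN(C(=O)c2ccc(-c3cccc(S(C)(=O)=O)c3)cc2)C(C)C)c1`: > 26000 nM, likewise a limit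

Compound 3 stands at the limit of this assay; its value is one of three limits and gives no number to set against compound 1 or compound 2. The steps among the measured compounds, a step that the two limits leave unreadable from compound 1 to compound 2, a step that the two limits leave unreadable from compound 1 to compound 3 and a step that the two limits leave unreadable from compound 2 to compound 3, cannot be read in size because of the limit of > 26000 nM in this assay, at which 3 of the 3 values shown sit. Compound 4 `CCOC(=O)CCCCCOc1cccc(CN(C(=O)c2ccc(-c3cccc(CC(=O)O)c3)cc2)C(C)C)c1` differs from compound 3 by carboxymethyl in place of methylsulfonyl on an aromatic carbon. For the measured compounds named here, the steps that bear on this change are those ending in compound 3, a step that the two limits leave unreadable from compound 1 to compound 3 and a step that the two limits leave unreadable from compound 2 to compound 3, and both are unreadable; three different groups at this place in the shared core all left the read-out at its limit. For compound 4 the step expected in this assay is a step that the limit leaves unreadable from compound 3 to compound 4, with no direction beyond the scatter to be read from what has been measured. Compound 4 is accordingly estimated at 45000 nM in this assay, within 15000 nM to 150000 nM, and is most likely to be reported again only as a limit.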

Compound 4, half-maximal effective concentration: > 26000 nM
Compound 4: no number, only a limit; the forecaster's own chance of this, stated with the estimate: 85%; the middle value does not contradict the limit.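

The steps from compound 1, compound 2 and compound 3 to compound 4 in this assay cannot be read, because all four compounds give a limit and not a number: the limit of > 26000 nM in this assay, at which 4 of the 4 values shown sit.

The compounds shown leave open how far apart these four lie, and whether any group at this place on the shared core gives a measurable value.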